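Swapping Naphthalen-1-yl for Furan-2-yl in Compound 2

The compounds below may be only part of what the source reports. "The series", "measured", "known", "first", "only" and "open" are said of these compounds alone.

Measured in a functional assay on THP-1 cells (Homo sapiens) for inhibition, read by sulforhodamine B assay, with a stated time of 48 h, tested at 50 uM; on this read-out higher numbers stand for more inhibition of growth at the one concentration tested and lower numbers for less inhibition of growth:
- compound 1 `COc1cc(/C=C/C(=O)/C=C/c2cccc3ccccc23)ccc1OCc1cn(CCCOc2cc(=O)oc3ccccc23)nn1`: 71%
- compound 2 `COc1cc(/C=C/C(=O)/C=C/c2cccc3ccccc23)ccc1OCc1cn(CCCCCOc2cc(=O)oc3ccccc23)nn1`: 44%
- compound 3 `COc1cc(/C=C/C(=O)/C=C/c2ccco2)ccc1OCc1cn(CCOc2cc(=O)oc3ccccc23)nn1`: 78%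

Compound 2, at 44%, is the lowest of the three, beyond the scatter from both others. Compound 4 `COc1cc(/C=C/C(=O)/C=C/c2ccco2)ccc1OCc1cn(CCCCCOc2cc(=O)oc3ccccc23)nn1` keeps its chain and makes one change: furan-2-yl in place of naphthalen-1-yl on a double-bonded chain carbon bound to a double-bonded chain carbon. Within the data shown here, no measured pair isolates this swap. Compound 3 carries furan-2-yl and gives 78%, but its chain also differs from that of compound 2. Compound 1 keeps naphthalen-1-yl and still gives 71%, so the gap cannot be credited to the swap alone. In this assay, a moderate rise slightly beyond the scatter is expected, a number 12 percentage points higher from compound 2 to compound 4 (beyond the scatter). Compound 4 is estimated at 56%, within an expected range of 38% to 74%.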

Compound 4, percent growth inhibition at one concentration: 39%
Compound 4: the middle estimate sits 17 percentage points above what was measured; measured number inside the range.
By their numbers in this assay, from the lowest: compounds 4 and 2 (each within the scatter of the next); then compounds 1 and 3 (each within the scatter of the next).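

In this assay, among these compounds, furan-2-yl in place of naphthalen-1-yl gives a number 5 percentage points lower from compound 2 to compound 4 (within the scatter), the first reading of this swap on its own. On this chain, the group on the double-bonded chain carbon can go from 10 heavy atoms to 5 and gain a hydrogen-bond acceptor without a change beyond the scatter. Nothing available accounts for this outcome. As far as these compounds go, whether the swap behaves the same on the shorter chains of compound 1 and compound 3 remains open. So does the effect of a phenyl or pyridin-3-yl group at this place.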